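Ethoxy in Place of Methylsulfonyl: A Side-Chain Swap

The source may report more compounds than this note shows. Statements on the series, on what has been measured and on what is new or still open speak of the compounds shown alone.

Going by the values given here, in a functional assay on CHO cells for agonist activity at Alpha-1A adrenergic receptor (Homo sapiens), read by fluorescence and calcium flux (on this read-out lower numbers stand for smaller maximal responses and higher numbers for larger maximal responses), three compounds have numbers so far. Compound 1 `CS(=O)(=O)Nc1c(Cl)ccc2c1CCCC2c1ncc[nH]1` gives 64%, compound 2 `Clc1ccc2c(c1-c1cn[nH]c1)CCC2c1ncc[nH]1` gives 52%, and compound 3 `CS(=O)(=O)Cc1cccc2c1CCC2c1ncc[nH]1` gives 70%. Compound 3 has the highest of these three numbers; its gap to compound 1 lies within the scatter, while its gap to compound 2 lies beyond it. Compound 4 `CCOCc1cccc2c1CCC2c1ncc[nH]1` has not yet been measured in this assay. It differs from compound 3 in one place: ethoxy in place of methylsulfonyl on a saturated chain carbon bound to an aromatic carbon. No step between two measured compounds is available, so the size of this change has no anchor among the numbers shown. The step from compound 3 to compound 4 is expected to be modest, a number 5 percentage points lower from compound 3 to compound 4 (within the scatter), with no direction that clearly exceeds the scatter. Compound 4 is expected to give about 65%, between 45% and 85%.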

Compound 4, largest response reached (Emax), in percent of the reference or control that the assay uses: 64%
Compound 4: middle estimate off by 1 percentage points, on the high side; measured number inside the range.
By their numbers in this assay, from the lowest: compound 2; then compounds 1, 4 and 3 (each within the scatter of the next).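

Going by these compounds alone, at the saturated chain carbon bound to an aromatic carbon, ethoxy in place of methylsulfonyl gives the first step that can be read in this assay, a number 6 percentage points lower from compound 3 to compound 4 (within the scatter), the only comparison here between compounds that differ in one place. For this pair, then, a response of this size does not depend on the methylsulfonyl group. No measured evidence bears on why the two groups compare in this way.

From the compounds shown here alone, whether an amine, a carboxylic acid or a longer chain at this place would give a similar response remains open. So does whether the same swap would give a similar step on another core.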